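Tertiary difluoropiperidine amide replaces secondary methoxycyclohexyl amide

A few compounds are considered here, and "the series" means these few. Any claim that something is new, unique, unknown or untested is made for them only; others in the source may bear on it.

Measured so far:
compound 1, `CCN(CC)S(=O)(=O)c1ccc(S(=O)(=O)N2CCC[C@@H](C(=O)NC3COC3)C2)cc1`, 13800 nM
compound 2, `CCN(CC)S(=O)(=O)c1ccc(S(=O)(=O)N2CCC[C@@H](C(=O)N[C@H]3CC[C@@H](OC)CC3)C2)cc1`, 2150 nM

Both compounds were tested in a functional assay on BXPC-3 cells (Homo sapiens) for inhibition, read by MTT assay, with a stated time of 7 days; on this read-out higher numbers stand for weaker inhibition and lower numbers for stronger inhibition. Going by the values given here, compound 2 gives the lowest of the two numbers in this assay, with compound 1 as its only neighbour; the step of a 6.4-fold lower number from compound 1 to compound 2 (0.81 log units; beyond the scatter) lies beyond the scatter, so compound 2 is the stronger inhibitor of the pair.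

Compound 3 is `CCN(CC)S(=O)(=O)c1ccc(S(=O)(=O)N2CCC[C@@H](C(=O)N3CCC(F)(F)CC3)C2)cc1`. It differs from compound 2 by 4,4-difluoropiperidin-1-yl in place of (4-methoxycyclohexyl)amino on a carbonyl carbon. Among the compounds with values here, the one measured step, a 6.4-fold lower number from compound 1 to compound 2 (0.81 log units; beyond the scatter), concerns a ring swap on the same amide-type nitrogen while that nitrogen kept its hydrogen; the present change instead folds the nitrogen into a ring and removes the donor. That step therefore bears on it only loosely. Within the data shown here, with no measured example of a tertiary amide, the estimate for compound 3 stays close to compound 2, leaning slightly towards a higher number and with a wide range; the expected step is a 1.6-fold higher number from compound 2 to compound 3 (0.21 log units; within the scatter). In this assay compound 3 is expected to give about 3500 nM, within a range from 1000 nM to 12000 nM.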

Compound 3, half-maximal inhibitory concentration: 120 nM
The estimate for compound 3 lay 29-fold (1.46 log units) above the measured number; the measured number lies below the stated range.
By their numbers in this assay, from the lowest: compound 3; then compound 2; then compound 1.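

Placing 4,4-difluoropiperidin-1-yl on the carbonyl carbon in place of (4-methoxycyclohexyl)amino gives an 18-fold lower number from compound 2 to compound 3 (1.25 log units; beyond the scatter) in this assay, the first change at this position in which the amide nitrogen loses its hydrogen and the entering group has no hydrogen-bond donor. Measured against the oxetane amide, the same group gives a 120-fold lower number from compound 1 to compound 3 (2.06 log units; beyond the scatter), so this position can carry a tertiary amide, and in compound 3 inhibition in this series does not depend on the amide hydrogen. Nothing measured here accounts for the gain, so the result stands as an observation about these compounds only.

The change from compound 2 to compound 3 alters several things at once: the amide hydrogen goes, the ring moves onto the nitrogen, the methoxy group is lost and two fluorine atoms arrive, and the compounds shown cannot apportion the step among them. An unsubstituted piperidin-1-yl amide would speak to the part played by the fluorine atoms, and a methyl group on the amide nitrogen of compound 2 would speak to the part played by the amide hydrogen.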